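The source may report more compounds than this note shows. Statements on the series, on what has been measured and on what is new or still open speak of the compounds shown alone.

Series notes. Compound 1 `COc1cc(N(C)C(=O)c2cccc([N+](=O)[O-])c2)cc(OC)c1OC` and compound 2 `COc1cc(NC(=O)c2cccc([N+](=O)[O-])c2)cc(OC)c1OC` share one core; compound 3 `COc1cc(N(C)C(=O)c2ccc([N+](=O)[O-])cc2)cc(OC)c1OC` and compound 4 `COc1cc(NC(=O)c2ccc([N+](=O)[O-])cc2)cc(OC)c1OC` share another, and the difference between the two cores is not broken down here. In a functional assay on ONS-76 cells (Homo sapiens) for cytotoxicity, read by MTT assay, with a stated time of 72 h (a lower number here means a stronger inhibitor, a higher number a weaker inhibitor), compound 1 gives >= 125000 nM, a limit of the assay. In this assay compound 2 gives >= 125000 nM, also a limit. In this assay compound 3 gives >= 125000 nM, again a limit. The change hydrogen in place of methyl on an amide-type nitrogen gives a step that the two limits leave unreadable from compound 1 to compound 2. The change hydrogen in place of methyl on an amide-type nitrogen is the same change at the same place. Because (the limit of >= 125000 nM in this assay, at which 3 of the 3 values shown sit), the measured step cannot be sized. For compound 4 the expected step is a number no higher from compound 3 to compound 4 (the limit leaves the size open), resting on compound 3 standing at >= 125000 nM. Compound 4 is estimated at 125000 nM, between 60000 nM and 200000 nM, and most likely again reported only as a limit.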

Compound 4, half-maximal inhibitory concentration: >= 125000 nM
Compound 4 ended at the assay's limit; the forecaster's own chance of this, stated with the estimate: 85%; the middle value lies on the limit itself.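

Among the compounds shown here, no step from compound 3 to compound 4 can be read in this assay, because both compounds stand at a limit: the limit of >= 125000 nM in this assay, at which 4 of the 4 values shown sit. The compounds shown leave open whether hydrogen in place of methyl on an amide-type nitrogen changes the read-out at all, on either core.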